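This account rests on a few compounds, and the source may have more. Where it says the series, first, only, none or still open, it means among the compounds named here.

Measured so far in this series:
compound 1 `Oc1cccc(-c2cc(-c3ccccc3)cc(-c3ccco3)n2)c1` gives 9430 nM in a functional assay on HeLa cells (Homo sapiens) for cytotoxicity, read by ELISA, with a stated time of 2 days; on this read-out higher numbers stand for weaker inhibition and lower numbers for stronger inhibition
compound 2 `Oc1ccc(-c2cc(-c3ccccc3)cc(-c3ccco3)n2)cc1` gives 10900 nM in this assay
compound 3 `Oc1cccc(-c2cc(-c3ccccc3)nc(-c3ccco3)c2)c1` gives 10900 nM in this assay

Compound 1 and compound 2 share one core and differ by 4-hydroxyphenyl in place of 3-hydroxyphenyl on an aromatic carbon. The step is a 1.2-fold higher number from compound 1 to compound 2 (0.06 log units; within the scatter). Compound 3 carries a second core; the difference between the core of compound 1 and the core of compound 3 is not broken down here. Compound 3 and compound 2 stand level at the digits given, and compound 3 and compound 1 lie within the scatter of each other, so all three numbers sit at about the same level.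

Compound 4 `Oc1ccc(-c2cc(-c3ccccc3)nc(-c3ccco3)c2)cc1` is not yet measured. It differs from compound 3 by 4-hydroxyphenyl in place of 3-hydroxyphenyl on an aromatic carbon. This is the same kind of change as from compound 1 to compound 2, but not the same: there the group sits next to the ring nitrogen, here opposite the ring nitrogen. In this assay the step from compound 3 to compound 4 is expected to be a 1.1-fold higher number from compound 3 to compound 4 (0.04 log units; within the scatter), because the matched step a 1.2-fold higher number from compound 1 to compound 2 (0.06 log units; within the scatter) stayed within the scatter. Compound 4 is thus expected to give 12000 nM, between 6000 nM and 25000 nM.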

Compound 4, half-maximal inhibitory concentration: 4500 nM
Estimate against measurement, compound 4: 2.7-fold (0.43 log units) above, and the stated range ends above it.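

In this assay, 4-hydroxyphenyl in place of 3-hydroxyphenyl gives a 2.4-fold lower number from compound 3 to compound 4 (0.38 log units; beyond the scatter), a modest step. The same change does not read the same on the two cores: the same change on two cores in this assay, a 1.2-fold higher number (0.06 log units; within the scatter) from compound 1 to compound 2 and a 2.4-fold lower number (0.38 log units; beyond the scatter) from compound 3 to compound 4, 2.8-fold (0.45 log units) apart, beyond the scatter of two such steps. Going by these compounds alone, a step read on the core of compound 1 therefore cannot be carried over unchanged to the core of compound 3 in this series, though this rests on only two matched pairs and does not show why the cores differ or whether the gap would hold for any other change or read-out.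

The compounds shown vary only between 3-hydroxyphenyl and 4-hydroxyphenyl, with phenyl and furan-2-yl kept throughout. Still open, going by these compounds, is how the two cores would respond to an amine or a carboxylic acid in place of the hydroxyl group, or to a longer chain in place of furan-2-yl.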